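Moving the chlorine of a chalcone from one ring position to another

The compounds below may be only part of what the source reports. "The series", "measured", "known", "first", "only" and "open" are said of these compounds alone.

Compound 1 `O=C(/C=C/c1ccccc1Cl)c1ccc(OCc2ccccc2)cc1` is one of two chalcones measured in a functional assay on CAL-51 cells (Homo sapiens) for inhibition, read by sulforhodamine B assay, with a stated time of 3 days (on this read-out higher numbers stand for weaker inhibition of growth and lower numbers for stronger inhibition of growth), where compound 1 gives 7100 nM. That is the higher of the two numbers: compound 2 `O=C(/C=C/c1ccc(F)cc1)c1ccccc1` gives 2780 nM in this assay, a lower number and a gap beyond the usual scatter, though the two structures differ in more than one place, so no single step can be read from them. Compound 3 `O=C(/C=C/c1ccc(Cl)cc1)c1ccc(OCc2ccccc2)cc1` keeps every atom of compound 1 and differs from it only in the change (4-chlorophenyl in place of 2-chlorophenyl on a double-bonded chain carbon bound to a double-bonded chain carbon). Among the compounds with values here, no comparable step is measured in this set, so the expected direction rests on the structures alone. The author expects a small change, with the step of a 1.4-fold lower number from compound 1 to compound 3 (0.15 log units; within the scatter) in this assay not clearly beyond the scatter. Compound 3 is therefore estimated to give 5000 nM in this assay, within a range from 1500 nM to 15000 nM.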

Compound 3, concentration for 50% growth inhibition: > 50000 nM
Compound 3 gave a limit, no number (the forecaster's own chance of this, stated with the estimate: 5%); middle value at least 10-fold (1.00 log units) from the limit.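

Within the data shown here, the two chlorophenyl isomers give the first comparison here that differs in one place, and it shows that this position is sensitive to where the chlorine sits even though no atom is gained or lost. In this assay, 4-chlorophenyl in place of 2-chlorophenyl on a double-bonded chain carbon bound to a double-bonded chain carbon gives an at least 7.0-fold higher number from compound 1 to compound 3 (0.84 log units; beyond the scatter), which means weaker inhibition of growth. Compound 3 sits at a limit of the assay and not at a number, so the full size of this step stays unknown: the limit of > 50000 nM in this assay, at which 1 of the 3 values shown sits.

From the compounds shown here alone, it remains open whether a methoxy group or an amine in place of the chlorine of compound 1 would keep the inhibition of growth. Among these compounds, compound 2 differs from both chlorine compounds in more than one place, so no step to it can be read.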